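Does a smaller amine on the carbonyl restore activity?

A few compounds are considered here, and "the series" means these few. Any claim that something is new, unique, unknown or untested is made for them only; others in the source may bear on it.

Measured in a functional assay on HCT-116 cells (Homo sapiens) for inhibition, read by MTT assay, with a stated time of 72 h; on this read-out higher numbers stand for weaker inhibition of growth and lower numbers for stronger inhibition of growth:
Compound 1 `CCOC(=O)/C=C/c1ccncc1-c1ccc2ccccc2c1`: 910 nM
Compound 2 `COC1CN(C(=O)/C=C/c2ccncc2-c2ccc3ccccc3c2)C1`: > 30000 nM

For compound 2, this assay gives only a limit and not a number: > 30000 nM. That position is the limit of > 30000 nM in this assay, at which 1 of the 2 values shown sits. Among the measured compounds shown here, the one measured step that bears on the next change is an at least 32-fold higher number from compound 1 to compound 2 (1.51 log units; beyond the scatter), which put 3-methoxyazetidin-1-yl in place of ethoxy on a carbonyl carbon.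

Compound 3 `CN(C)C(=O)/C=C/c1ccncc1-c1ccc2ccccc2c1` has dimethylamino in place of 3-methoxyazetidin-1-yl on that carbonyl carbon (dimethylamino in place of 3-methoxyazetidin-1-yl on a carbonyl carbon). It does not regain the ethoxy of compound 1, which gives 910 nM. Only a small step towards lower numbers is therefore expected, perhaps none beyond the scatter, and another limit is quite possible. The expected change is an at least 1.5-fold lower number from compound 2 to compound 3 (0.17 log units; that floor lies within the scatter). For compound 3 the estimated value is 20000 nM, within an expected range of 6000 nM to 30000 nM.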

Compound 3, concentration for 50% growth inhibition: 4540 nM
For compound 3 the middle estimate is 4.4-fold (0.64 log units) above the measured one, and the stated range ends above it.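

In this assay, dimethylamino on the carbonyl carbon brings back measurable inhibition of growth, with an at least 6.6-fold lower number from compound 2 to compound 3 (0.82 log units; beyond the scatter). On these data alone, the true size of this step remains unknown, since compound 2 has only a limit and not a number: the limit of > 30000 nM in this assay, at which 1 of the 3 values shown sits. A nitrogen on this carbonyl carbon therefore does not by itself remove activity, although ethoxy still gives the lower number, with a 5.0-fold higher number from compound 1 to compound 3 (0.70 log units; beyond the scatter).

The compounds shown leave open whether the recovery is tied to losing the four-membered ring, the methoxy group or both, as these parts change together between the two groups. An unsubstituted azetidin-1-yl group on the same carbonyl carbon would help separate these parts, and a pyrrolidin-1-yl group would show whether a larger ring on that nitrogen is tolerated.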